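This account rests on a few compounds, and the source may have more. Where it says the series, first, only, none or still open, it means among the compounds named here.

In a functional assay on HeLa cells (Homo sapiens) for cytotoxicity, read by CCK-8 assay (a lower number here means a stronger inhibitor, a higher number a weaker inhibitor), compound 2 `Oc1ccc(-c2cc(-c3ccoc3)cc(-c3ccc(O)cc3)n2)cc1` gives 3420 nM. Its only companion, compound 1 `Oc1ccc(-c2cc(-c3ccoc3)cc(-c3cccc(O)c3)n2)cc1`, gives 3310 nM, so the two sit within the scatter of each other, as the step of a 1.0-fold higher number from compound 1 to compound 2 (0.01 log units; within the scatter) shows. Compound 3 `Oc1ccc(-c2cc(-c3ccccn3)cc(-c3ccc(O)cc3)n2)cc1` differs from compound 2 by pyridin-2-yl in place of furan-3-yl on an aromatic carbon. Among the measured compounds shown here, no measured step touches this group: the one recorded step, a 1.0-fold higher number from compound 1 to compound 2 (0.01 log units; within the scatter), concerns a hydroxyphenyl group and was within the scatter. With nothing pointing either way, compound 3 is expected to give about 3400 nM, between 1200 nM and 10000 nM. The resulting step, a 1.0-fold lower number from compound 2 to compound 3 (0.00 log units; within the scatter), is expected to stay within the scatter.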

Compound 3, half-maximal inhibitory concentration: > 50000 nM
Compound 3: no number, only a limit; the forecaster's own chance of this, stated with the estimate: 10%; middle value at least 14-fold (1.16 log units) from the limit.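

In this assay the change from furan-3-yl to pyridin-2-yl gives an at least 14-fold higher number from compound 2 to compound 3 (1.16 log units; beyond the scatter) and so shows that the group opposite the ring nitrogen matters, which the earlier hydroxyphenyl change, within the scatter, could not show. Both groups have the same counts of hydrogen-bond donors and acceptors, so those counts do not separate them. The reading for compound 3 is a limit, not a number: the limit of > 50000 nM in this assay, at which 1 of the 3 values shown sits.

As far as these compounds go, the true size of the step therefore stays unknown. From the compounds shown here alone, whether a plain phenyl or pyridin-3-yl here would match compound 2 also stays open, so ring size and the ring nitrogen cannot yet be told apart.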